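The source may report more compounds than this note shows. Statements on the series, on what has been measured and on what is new or still open speak of the compounds shown alone.

Two members of the series have been measured in a functional assay on DU-145 cells (Homo sapiens) for antiproliferative activity, read by MTT assay, with a stated time of 24 h; a lower number here means a stronger inhibitor, a higher number a weaker inhibitor. Compound 1 `COc1ccc(-c2cc(C(=O)/C=C/c3ccc(C)cc3)nc3cc(-c4ccccc4)nn23)cc1OC` gives 19500 nM. Compound 2 `COc1ccc(C(=O)/C=C/c2cc(-c3ccc(OC)c(OC)c3)n3nc(-c4ccccc4)cc3n2)cc1OC` gives 7200 nM, the lower of the two numbers, with the number for compound 1 standing higher by a gap beyond the scatter; these two compounds differ in more than one place, so their values are only set side by side. Compound 3 `COc1ccc(-c2cc(/C=C/C(=O)c3ccccc3)nc3cc(-c4ccccc4)nn23)cc1OC` has not been measured. It differs from compound 2 by phenyl in place of 3,4-dimethoxyphenyl on a carbonyl carbon. Among the measured compounds shown here, no measured pair carries this change, so only a small shift toward a higher number is expected, a 1.7-fold higher number from compound 2 to compound 3 (0.22 log units; within the scatter). Compound 3 is expected to give about 12000 nM, within 5000 nM to 30000 nM.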

Compound 3, half-maximal inhibitory concentration: 10000 nM
Compound 3: the middle estimate sits 1.2-fold (0.08 log units) above what was measured; the range from low to high includes it.
By their numbers in this assay, from the lowest: compounds 2, 3 and 1 (each within the scatter of the next, the first and the last beyond it).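

In this assay, phenyl in place of 3,4-dimethoxyphenyl on a carbonyl carbon gives a 1.4-fold higher number from compound 2 to compound 3 (0.14 log units; within the scatter), so this pair does not separate the two groups at this position. The change of 2-benzoylethenyl in place of (2-(4-methylphenyl)ethenyl)carbonyl on an aromatic carbon gives a 2.0-fold lower number from compound 1 to compound 3 (0.29 log units; within the scatter), and this step also stays inside the scatter. No measurement is available that bears on either step. Still open, from the compounds shown here alone, is whether an amine or a carboxylic acid on the phenyl of compound 3 would shift the number beyond the scatter.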